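Isobutylcarbonyl to butyl on the ring nitrogen

The source may report more compounds than this note shows. Statements on the series, on what has been measured and on what is new or still open speak of the compounds shown alone.

Measured so far:
compound 1, `COc1ccccc1-c1cnc(N)nc1-c1ccccc1`: 20%
compound 2, `CC(C)CC(=O)Nc1ncc(-c2cccc(Cl)c2)c(-c2ccccc2)n1`: 56%

Of the compounds shown here, two have been tested in an assay on CHO cells for displacement of a labelled ligand from adenosine receptor A1 (Homo sapiens), read by scintillation counting, with a stated time of 1 h, tested at 1 uM; a higher number here means more inhibition at the concentration tested (going by the name of the read-out), a lower number less inhibition. Compound 1 `COc1ccccc1-c1cnc(N)nc1-c1ccccc1` gives 20% there, and compound 2 `CC(C)CC(=O)Nc1ncc(-c2cccc(Cl)c2)c(-c2ccccc2)n1` gives 56%. Compound 2 therefore holds the higher of the two numbers, and its gap to compound 1 lies beyond the usual scatter of such measurements. Compounds 1 and 2 differ in more than one place, so no single-step comparison between measured compounds exists, and nothing measured isolates the part played by the group on the nitrogen on the aromatic ring.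

Compound 3 `CCCCNc1ncc(-c2cccc(Cl)c2)c(-c2ccccc2)n1` has not yet been measured. It differs from compound 2 in one place: butyl in place of isobutylcarbonyl on a nitrogen on an aromatic ring. The carbonyl is gone and a butyl chain stays in its place. With compound 2 at 56% as the nearest measured point, and compound 1 at 20% showing that the core itself can read low, compound 3 is expected to sit somewhat below compound 2, a step of a number 16 percentage points lower from compound 2 to compound 3 (beyond the scatter) that may or may not exceed the scatter. Compound 3 is estimated at 40%, within a range from 15% to 65%.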

Compound 3, a percentage reported as inhibition, at one concentration (the size of the read-out at that concentration, not a potency): 56%
Beside the measured number, compound 3's estimate is 16 percentage points below it; measured number inside the range.
By their numbers in this assay, from the lowest: compound 1; then compounds 2 and 3 (each within the scatter of the next).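

In this assay, within the data shown here, replacing isobutylcarbonyl with butyl on a nitrogen on an aromatic ring gives no change at the digits printed from compound 2 to compound 3 (within the scatter), the first comparison that isolates this position. The carbonyl present in compound 2 and absent from compound 3 is therefore not required to retain this level of inhibition at the concentration tested, and neither is the amide link that it forms with the ring-bound nitrogen. Nothing in the data explains why these two groups read alike.

On these data alone, it remains open whether a shorter chain such as ethyl, a benzyl group, a chain ending in an amine or a carboxylic acid, or the bare amino group on the same nitrogen would also read like compound 2 and compound 3, which would show how much the substituent contributes at all. Because this read-out comes from a single concentration, it also leaves open whether compound 2 and compound 3 would match in a full potency measurement or in binding to other adenosine receptors.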